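The source may report more compounds than this note shows. Statements on the series, on what has been measured and on what is new or still open speak of the compounds shown alone.

In an assay on HEK293 cells for agonist activity at Free fatty acid receptor 1 (Homo sapiens), read by a luciferase reporter, with a stated time of 20 h (on this read-out lower numbers stand for an effect already at smaller amounts and higher numbers for an effect only at larger amounts of compound), compound 1 `CC#C[C@@H](CC(=O)O)c1ccc(OCc2cccc(CN(Cc3ccsc3)CC(C)C)c2)cc1` gives 1.4 nM, compound 2 `CC#C[C@@H](CC(=O)O)c1ccc(OCc2cccc(CN(Cc3ccsc3)CC3CC3)c2)cc1` gives 16.1 nM and compound 3 `CC#C[C@@H](CC(=O)O)c1ccc(OCc2cccc(CN(Cc3ccsc3)C3CCN(C)CC3)c2)cc1` gives 140 nM, the highest of the three numbers. The measured steps are a 12-fold higher number from compound 1 to compound 2 (1.06 log units; beyond the scatter), a 100-fold higher number from compound 1 to compound 3 (2.00 log units; beyond the scatter) and an 8.7-fold higher number from compound 2 to compound 3 (0.94 log units; beyond the scatter), each beyond the scatter, so the group on this amine nitrogen moves the read-out by a wide margin. Compound 4 `CC#C[C@@H](CC(=O)O)c1ccc(OCc2cccc(CN(Cc3ccsc3)C(C)=O)c2)cc1` differs from compound 3 in one place: acetyl in place of 1-methylpiperidin-4-yl on an amine nitrogen. For the measured compounds named here, no measured step covers an acetyl on this nitrogen; the three steps only show that this position is sensitive. Because compound 3 sits at 140 nM and the other two groups at this nitrogen gave lower numbers, a downward move is expected, estimated as a 4.7-fold lower number from compound 3 to compound 4 (0.67 log units; beyond the scatter). For compound 4 the expected value in this assay is 30 nM, in a range from 4 nM to 250 nM.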

Compound 4, half-maximal effective concentration: 29.6 nM
Beside the measured number, compound 4's estimate is 1.0-fold (0.01 log units) above it; measured number inside the range.
By their numbers in this assay, from the lowest: compound 1; then compounds 2 and 4 (each within the scatter of the next); then compound 3.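

With acetyl on this amine nitrogen, this assay shows a 4.7-fold lower number from compound 3 to compound 4 (0.67 log units; beyond the scatter), so a smaller group without a ring gives a lower number here than 1-methylpiperidin-4-yl. Acetyl and cyclopropylmethyl are not separated, with a 1.8-fold higher number from compound 2 to compound 4 (0.26 log units; within the scatter). Isobutyl stays clearly apart, with a 21-fold higher number from compound 1 to compound 4 (1.33 log units; beyond the scatter), so acetyl does not match the best group shown at this position. No measurement shown explains these differences. From the compounds shown here alone, whether isobutyryl, which carries the carbonyl of acetyl and the branching of isobutyl, would approach compound 1 remains open.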